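The compounds below may be only part of what the source reports. "The series", "measured", "known", "first", "only" and "open" are said of these compounds alone.

Compound 1 `Cc1cc(Cl)cc(-c2c(C)nn(-c3nc(-c4ccc(Cl)c(Cl)c4)c(SC(C)C)s3)c2C(=O)O)c1` is the reference point of this note. Among the measured compounds shown here, in a functional assay on BJAB cells (Homo sapiens) for antiproliferative activity, with a stated time of 4 days (a lower number here means that less compound is needed, a higher number that more compound is needed for the effect), compound 1 gives 663 nM, the lowest of the three numbers measured so far. Compound 3 `COC(=O)c1c(Cc2ccccc2[N+](=O)[O-])c(C)nn1-c1nc(-c2ccc(Cl)c(Cl)c2)c(SC(C)C)s1` gives 93000 nM and compound 2 `CCSc1sc(-n2nc(C)c(Cc3ccccc3[N+](=O)[O-])c2C(=O)OC)nc1-c1ccc(Cl)c(Cl)c1` gives 106000 nM; both gaps to compound 1 are far beyond the scatter, so compound 1 is the most potent of the measured set. For the measured compounds named here, the only measured step between closely related structures, a 1.1-fold lower number from compound 2 to compound 3 (0.06 log units; within the scatter), concerns a saturated chain carbon bound to a sulfur and leaves the aromatic ring untouched.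

Compound 4 `COc1cc(Cl)cc(-c2c(C)nn(-c3nc(-c4ccc(Cl)c(Cl)c4)c(SC(C)C)s3)c2C(=O)O)c1` differs from compound 1 in one place: methoxy in place of methyl on an aromatic carbon. Going by the values given here, no measured step bears on this change; the single step available lies within the scatter and sits elsewhere in the molecule, so the data give no direction for the exchange of methyl for methoxy. The expected step of a 1.1-fold higher number from compound 1 to compound 4 (0.02 log units; within the scatter) is therefore set within the scatter, with a wide range reflecting the absence of any precedent. Compound 4 is estimated at 700 nM in this assay, with a range from 200 nM to 2500 nM.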

Compound 4, half-maximal effective concentration: 760 nM
Estimate against measurement, compound 4: 1.1-fold (0.04 log units) below; low and high end bracket the measured number.
By their numbers in this assay, from the lowest: compounds 1 and 4 (each within the scatter of the next); then compounds 3 and 2 (each within the scatter of the next).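

At the aromatic carbon meta to a chloro group and meta to a large group, this assay now gives a direct reading of one exchange, methoxy in place of methyl, as a 1.1-fold higher number from compound 1 to compound 4 (0.06 log units; within the scatter) and so within the scatter. The earlier compounds shown here offered only a step on the saturated chain bound to sulfur and said nothing about this ring; here, 3-chloro-5-methylphenyl and 3-chloro-5-methoxyphenyl cannot be told apart in this read-out, even though the entering group adds a heavy atom and a hydrogen-bond acceptor. No measured evidence is available to explain this outcome.

On these data alone, whether this position accepts other groups remains open: an amine, a hydroxyl group or a longer chain such as ethoxy could each read differently, and so could a replacement of the neighbouring substituent pattern, for example fluoro in place of the chloro group. As far as these compounds go, the reading also rests on a single matched pair in one cell assay, so whether the same exchange gives the same result with changes elsewhere on the core is unknown.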